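Unmasking the Amine: From Compound 1 to Compound 4

This account rests on a few compounds, and the source may have more. Where it says the series, first, only, none or still open, it means among the compounds named here.

Measured compounds:
compound 1 `CCn1nc(C)cc1C(=O)Nc1nc2cc(C(N)=O)cc(OC)c2n1CCCNC(=O)OCc1ccccc1` — > 100000 nM
compound 2 `COc1cc(C(N)=O)cc2nc(NC(=O)c3ccccn3)n(CCCNC(=O)OCc3ccccc3)c12` — > 100000 nM
compound 3 `COc1cc(C(N)=O)cc2nc(NC(=O)c3cccnn3)n(CCCNC(=O)OCc3ccccc3)c12` — > 100000 nM

In an assay for activation of interferon regulatory factor 3 (Homo sapiens), read by a luciferase reporter, with a stated time of 20 h (a higher number here means that more compound is needed for the effect, a lower number that less compound is needed), compound 1 gives only a limit of the assay, > 100000 nM. Compound 2 also stops at a limit, > 100000 nM. Compound 3 likewise stops at a limit, > 100000 nM. All three values therefore rest on (the limit of > 100000 nM in this assay, at which 3 of the 3 values shown sit), so the steps a step that the two limits leave unreadable from compound 1 to compound 2, a step that the two limits leave unreadable from compound 1 to compound 3 and a step that the two limits leave unreadable from compound 2 to compound 3 carry no readable size. None of them touches the amine that changes on the way to compound 4 `CCn1nc(C)cc1C(=O)Nc1nc2cc(C(N)=O)cc(OC)c2n1CCCN`, whose change is hydrogen in place of benzyloxycarbonyl on an amine nitrogen. Going by the values given here, no measured step bears on this change, so the direction of an at least 5.0-fold lower number from compound 1 to compound 4 (0.69 log units; beyond the scatter) is an open expectation. Compound 4 is estimated at 20000 nM, within 500 nM to 100000 nM.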

Compound 4, half-maximal effective concentration: > 100000 nM
Compound 4 gave a limit, no number; the forecaster's own chance of this, stated with the estimate: 45%; middle value at least 5.0-fold (0.69 log units) from the limit.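

Compound 4 also stops at a limit, > 100000 nM, so no size can be read for its step from compound 1: the limit of > 100000 nM in this assay, at which 4 of the 4 values shown sit. The compounds shown leave open whether hydrogen in place of benzyloxycarbonyl changes anything in this assay.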